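Compound 4: trimethylphenyl in place of dichlorophenyl

The source may hold more compounds than are shown below. What is called first, only, known or untested is meant among the compounds shown, and "the series" means these compounds.

Measured in a functional assay on HeLa cells (Homo sapiens) for inhibition, read by MTT assay, with a stated time of 48 h; on this read-out higher numbers stand for weaker inhibition and lower numbers for stronger inhibition:
compound 1 `O=C(CC(c1ccc(Cl)cc1)C(C(=O)Nc1ccccn1)C(=O)Nc1ccccn1)c1ccc(F)cc1` gives 4100 nM as its value
compound 2 `O=C(CC(c1cccs1)C(C(=O)Nc1ccccn1)C(=O)Nc1ccccn1)c1ccccc1` gives "not active" (no number reported) with no number reported
compound 3 `O=C(CC(c1ccc(Cl)cc1Cl)C(C(=O)Nc1ccccn1)C(=O)Nc1ccccn1)c1ccccc1` gives 13500 nM as its value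

Compound 3 at 13500 nM holds the higher of the two numbers, so it inhibits more weakly than compound 1 at 4100 nM by a gap beyond the usual scatter. Compound 4 `Cc1cc(C)c(C(CC(=O)c2ccccc2)C(C(=O)Nc2ccccn2)C(=O)Nc2ccccn2)c(C)c1` keeps the shared core but carries 2,4,6-trimethylphenyl in place of 2,4-dichlorophenyl on a saturated chain carbon bound to two saturated chain carbons here. For the measured compounds named here, no measured pair differs in one place only, so the data offer no direct guide. The expected change in this assay is therefore small, an estimated 1.2-fold lower number from compound 3 to compound 4 (0.09 log units; within the scatter) and none beyond the scatter. Compound 4 is estimated at 11000 nM with an expected range from 3500 nM to 35000 nM in all.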

Compound 4, half-maximal inhibitory concentration: 15100 nM
Estimate against measurement, compound 4: 1.4-fold (0.14 log units) below, within the range that was stated.
By their numbers in this assay, from the lowest: compound 1; then compounds 3 and 4 (each within the scatter of the next).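

In this assay, putting 2,4,6-trimethylphenyl in place of 2,4-dichlorophenyl on a saturated chain carbon bound to two saturated chain carbons gives a 1.1-fold higher number from compound 3 to compound 4 (0.05 log units; within the scatter). For the compounds shown here, this is the only one-place comparison at this position so far, and it shows that an all-carbon substituted ring and a chlorine-bearing one can read alike here. Nothing measured explains this result.
From the compounds shown here alone, whether a ring carrying an amine or a carboxylic acid would read the same at this position remains open. So does whether any change here could bring a number beyond the scatter.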